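A few compounds are considered here, and "the series" means these few. Any claim that something is new, unique, unknown or untested is made for them only; others in the source may bear on it.

Compound 1 `CNC(=O)[C@H]1O[C@@H](n2cnc3c(NC)nc(Cl)nc32)[C@H](O)[C@@H]1O` gives 0.282 nM in an assay on CHO cells for displacement of a labelled ligand from adenosine receptor A3 (Homo sapiens); a lower number here means a stronger inhibitor, a higher number a weaker inhibitor. Compound 2 `CNC(=O)[C@H]1O[C@@H](n2cnc3c(NC4CC4)nc(Cl)nc32)[C@H](O)[C@@H]1O` gives 2.24 nM in this assay, and compound 3 `CNC(=O)[C@H]1O[C@@H](n2cnc3c(NCc4ccccc4C)nc(Cl)nc32)[C@H](O)[C@@H]1O` gives 2.19 nM. Compound 3 differs from compound 1 by 2-methylphenyl in place of hydrogen on a saturated chain carbon bound to a nitrogen on an aromatic ring, a change that gave a 7.8-fold higher number from compound 1 to compound 3 (0.89 log units; beyond the scatter); compound 2 and compound 3 show a 1.0-fold lower number from compound 2 to compound 3 (0.01 log units; within the scatter). Compound 4 `Cc1ccccc1CNc1nc(Cl)nc2c1ncn2[C@@H]1O[C@H](C(=O)NC2CC2)[C@@H](O)[C@H]1O` has not yet been measured in this assay; it differs from compound 3 by cyclopropyl in place of methyl on an amide-type nitrogen. The same kind of change, (cyclopropyl in place of methyl on a nitrogen on an aromatic ring), has occurred once before and gave a 7.9-fold higher number from compound 1 to compound 2 (0.90 log units; beyond the scatter). It is not the same change: there the place was a nitrogen on an aromatic ring whose other neighbours are aromatic carbon, whereas in compound 4 the place is an amide-type nitrogen whose other neighbours are carbonyl carbon. A step of a 2.3-fold higher number from compound 3 to compound 4 (0.36 log units; beyond the scatter) is expected for compound 4, resting on the earlier step of a 7.9-fold higher number from compound 1 to compound 2 (0.90 log units; beyond the scatter) and on the different place of the present change. Compound 4 is estimated at 5 nM, between 1.5 nM and 20 nM.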

Compound 4, inhibition constant: 27.5 nM
Beside the measured number, compound 4's estimate is 5.5-fold (0.74 log units) below it, and the stated range ends below it.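

Cyclopropyl in place of methyl on the amide-type nitrogen gave a 13-fold higher number from compound 3 to compound 4 (1.10 log units; beyond the scatter) in this assay, and this rise matches in size the one seen when the same swap was made on the nitrogen on an aromatic ring: the same change on two cores in this assay, a 7.9-fold higher number (0.90 log units; beyond the scatter) from compound 1 to compound 2 and a 13-fold higher number (1.10 log units; beyond the scatter) from compound 3 to compound 4, 1.6-fold (0.20 log units) apart, within the scatter of two such steps. Within these compounds, the swap therefore weakened binding by a comparable amount at both places and on both cores. Among the compounds shown here, this rests on only one pair at each place, however, so it does not show that the step would carry over to other cores, and it does not explain why the number rises. The compounds shown leave open whether ethyl or isopropyl on the amide-type nitrogen would act as cyclopropyl does. They also leave open whether the step would hold with plain benzyl on the other nitrogen.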